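Branching on the nitrogen and tolerated concentration

The source may report more compounds than this note shows. Statements on the series, on what has been measured and on what is new or still open speak of the compounds shown alone.

Measured in an ADME assay on C8166 cells (Homo sapiens) for cytotoxicity, read by MTT assay; a lower number here means that less compound is tolerated, a higher number that more compound is tolerated:
- compound 1 `CCCn1cc(C(=O)O)c(=O)c2c(O)c(Cc3cccc(Cl)c3F)ccc21`: 24200 nM
- compound 2 `CCC(C)n1cc(C(=O)O)c(=O)c2c(O)c(Cc3cccc(Cl)c3F)ccc21`: 30700 nM

Among the measured compounds shown here, compound 2 stands level with compound 1, as the only measured step, a 1.3-fold higher number from compound 1 to compound 2 (0.10 log units; within the scatter), does not separate them. Compound 3 `CC(C)(C)n1cc(C(=O)O)c(=O)c2c(O)c(Cc3cccc(Cl)c3F)ccc21` has not yet been measured. It keeps the shared core and has tert-butyl in place of sec-butyl on an aromatic nitrogen.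

For the measured compounds named here, only one measured step bears on this change. It places a methyl in place of hydrogen on the saturated chain carbon bound to the aromatic nitrogen, and it stayed small, at a 1.3-fold higher number from compound 1 to compound 2 (0.10 log units; within the scatter). That is thin evidence, since it is a single pair and the new group is joined differently from anything tested so far. Nothing in these data points to a shift in either direction, so no step beyond the scatter is expected in this assay. The expected step is a 1.0-fold higher number from compound 2 to compound 3 (0.02 log units; within the scatter). For compound 3 the estimated value is 32000 nM, with an expected range of 16000 nM to 64000 nM.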

Compound 3, half-maximal cytotoxic concentration: 400000 nM
For compound 3 the middle estimate is 13-fold (1.10 log units) below the measured one, outside the stated range (above it).
By their numbers in this assay, from the lowest: compounds 1 and 2 (each within the scatter of the next); then compound 3.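

The aromatic nitrogen proved far less indifferent to branching than the earlier pair suggested: in this assay the move from sec-butyl to tert-butyl gives a 13-fold higher number from compound 2 to compound 3 (1.11 log units; beyond the scatter) even though the two groups hold the same atoms, joined differently. The earlier methyl on the chain carbon bound to that nitrogen had given only a 1.3-fold higher number from compound 1 to compound 2 (0.10 log units; within the scatter) and so left propyl and sec-butyl level, while the comparison with propyl gives a 17-fold higher number from compound 1 to compound 3 (1.22 log units; beyond the scatter) and sets compound 3 clearly apart from both. Among these compounds, then, the arrangement of the carbons on the nitrogen matters more than their number, and the change in this assay appears only with tert-butyl; nothing available gives a reason for this jump.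

As far as these compounds go, it remains open whether the higher tolerated concentration belongs to tert-butyl alone or extends to other groups on this nitrogen, such as 1-methylcyclopropyl or a longer branched chain like tert-pentyl. These three compounds also cannot show whether the same change would hold on a core carrying something other than the carboxylic acid, such as an amide or an ester.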